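Adding a methoxy group to a benzamide agonist

The source may hold more compounds than are shown below. What is called first, only, known or untested is meant among the compounds shown, and "the series" means these compounds.

Compound 1 `COc1ccccc1C(=O)NCCNc1cccc(NS(=O)(=O)c2cc(-c3cccc(C(=O)N(C)C)c3)ccc2OC)c1` gives 46% in a functional assay on CHO-K1 cells for agonist activity at Orexin/Hypocretin receptor type 1 (Homo sapiens), read by calcium flux; a higher number here means a larger maximal response, a lower number a smaller maximal response. Compound 2 `COc1ccc(-c2cccc(C(=O)N(C)C)c2)cc1S(=O)(=O)Nc1cccc(NCCNC(=O)c2ccccc2)c1` carries a benzamido end without any substituent, and in this assay compound 2 gives "not determined" (no result reported), so there is no fixed point from which to measure a step. Compound 3 `COc1cccc(C(=O)NCCNc2cccc(NS(=O)(=O)c3cc(-c4cccc(C(=O)N(C)C)c4)ccc3OC)c2)c1` arises from compound 2 through (methoxy in place of hydrogen on an aromatic carbon). Within the data shown here, because no step between measured compounds is known, the change is expected to move the maximal response little, in no clear direction, and likely within the usual scatter. The maximal response of compound 3 is estimated at 42%, within 15% to 75%.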

Compound 3, largest response reached (Emax), in percent of the reference or control that the assay uses: 49%
Estimate against measurement, compound 3: 7 percentage points below, within the range that was stated.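

Placing the methoxy group as 3-methoxyphenyl rather than 2-methoxyphenyl gives a first comparison at this end of the molecule: in this assay there is a number 3 percentage points higher from compound 1 to compound 3 (within the scatter) and so the two placements cannot be told apart. Compound 2 has no value, so the step from hydrogen to methoxy cannot be read. No measurement shown offers an explanation for this result. As far as these compounds go, whether an amine, a carboxylic acid or a longer chain on this aromatic ring would give a different maximal response remains open.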